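Furan-2-yl in place of phenyl on the carbonyl carbon

A few compounds are considered here, and "the series" means these few. Any claim that something is new, unique, unknown or untested is made for them only; others in the source may bear on it.

In a functional assay on NCI-H460 cells (Homo sapiens) for cytotoxicity (on this read-out lower numbers stand for stronger inhibition and higher numbers for weaker inhibition), compound 1 `COc1ccc(S(=O)(=O)N2CCc3cccc(NC(C)=O)c32)cc1` gives 75 nM and compound 3 `COc1ccc(S(=O)(=O)N2CCc3cccc(NC(=O)c4ccccc4)c32)cc1` gives 257 nM. Compound 3 therefore holds the higher of the two true numbers in the series, and so the weaker inhibition.

Compound 2 `COc1ccc(S(=O)(=O)N2CCc3cccc(NCc4ccccc4)c32)cc1` returns only a limit, > 10000 nM.

The next analogue is compound 4 `COc1ccc(S(=O)(=O)N2CCc3cccc(NC(=O)c4ccco4)c32)cc1`, with furan-2-yl in place of phenyl on a carbonyl carbon.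

Among the compounds with values here, the closest precedent is a change at the same place, a 3.4-fold higher number from compound 1 to compound 3 (0.53 log units; beyond the scatter), which is modest and beyond the scatter. Two large steps, an at least 130-fold higher number from compound 1 to compound 2 (2.12 log units; beyond the scatter) and an at least 38-fold lower number from compound 2 to compound 3 (1.59 log units; beyond the scatter), involve loss or return of the carbonyl. Compound 4 keeps that carbonyl, so these two steps bear on it only weakly.

The group entering compound 4 is a single aromatic ring, like the phenyl it replaces, and only compound 1 shows a lower number with a different group at this place, at 75 nM. A small move toward lower numbers is expected, but none beyond the scatter.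

The expected step is a 1.7-fold lower number from compound 3 to compound 4 (0.23 log units; within the scatter).

For compound 4 the estimated value is 150 nM, with an expected range from 45 nM to 550 nM.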

Compound 4, half-maximal inhibitory concentration: 9.8 nM
Compound 4: middle estimate off by 15-fold (1.18 log units), on the high side; the measured number lies below the stated range.
By their numbers in this assay, from the lowest: compound 4; then compound 1; then compound 3. At a limit, above all of these: compound 2.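

In this assay, the identity of the ring on the carbonyl carbon matters and not just its presence: a 26-fold lower number from compound 3 to compound 4 (1.42 log units; beyond the scatter), although furan-2-yl and phenyl are each a single aromatic ring. The earlier pair could be read as a ring here costing against methyl, but a 7.7-fold lower number from compound 1 to compound 4 (0.88 log units; beyond the scatter), so that reading holds for phenyl alone, and compound 4 goes against it. Set against the limit at the top of the series, an at least 1000-fold lower number from compound 2 to compound 4 (3.00 log units; beyond the scatter) is a bound and not a measured gap: the limit of > 10000 nM in this assay, at which 1 of the 4 values shown sits.

The compounds shown cannot say whether the lower number of compound 4 follows from the ring oxygen, which brings the one hydrogen-bond acceptor counted for furan-2-yl, or from the five-membered ring itself; thiophen-2-yl would keep the five-membered ring without the oxygen, and pyridin-2-yl would keep a hetero atom in a six-membered ring. Also open, on these data alone, is how much the furan-2-yl ring tolerates further substitution, for instance a methyl or a bromine on it, and whether the amide hydrogen is needed, which an N-methyl amide would test.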